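Swapping ethylamino for ethoxy on a carbonyl carbon

The compounds below may be only part of what the source reports. "The series", "measured", "known", "first", "only" and "open" are said of these compounds alone.

In an in vitro ADME assay on microsomes from liver (Rattus norvegicus) for metabolic stability (a higher number here means faster removal of the compound, a lower number slower removal), compound 2 (`CCNC(=O)[C@H]1CC[C@@H](n2/c(=N/C(=O)c3ccccc3)[nH]c3ccc(CN4CCCCC4)cc32)CC1`) gives 310 mL.min-1.g-1 as its result. For the measured compounds named here, that lies close to compound 1 (`CC(C)NC(=O)[C@H]1CC[C@@H](n2/c(=N/C(=O)c3ccccc3)[nH]c3ccc(CN4CCCCC4)cc32)CC1`), which gives 389 mL.min-1.g-1 here, and these two sit at the high end of the three known numbers. Compound 3 (`CC(C)NC(=O)[C@H]1CC[C@@H](n2/c(=N/C(=O)c3cc(F)cc(C#N)c3)[nH]c3ccc(CN4CCC(C(C)(C)O)CC4)cc32)CC1`) reads far lower, with 30 mL.min-1.g-1 on record.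

Compound 4 (`CCOC(=O)[C@H]1CC[C@@H](n2/c(=N/C(=O)c3ccccc3)[nH]c3ccc(CN4CCCCC4)cc32)CC1`) differs from compound 2 in one place: ethoxy in place of ethylamino on a carbonyl carbon here.

Going by the values given here, the one measured single change, a 1.3-fold lower number from compound 1 to compound 2 (0.10 log units; within the scatter), stays within the scatter. It alters the chain on the amide-type nitrogen, though, and keeps that nitrogen. Among the compounds with values here, no measured pair swaps ethylamino for ethoxy, so the guidance is weak. A step within the scatter, slightly upward if anything, is therefore expected in this assay for now. The expected change is a 1.5-fold higher number from compound 2 to compound 4 (0.16 log units; within the scatter) and remains uncertain. The estimate for compound 4 is 450 mL.min-1.g-1 with an expected range of 200 mL.min-1.g-1 to 1000 mL.min-1.g-1 until the measurement arrives.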

Compound 4, intrinsic clearance in microsomes: 706 mL.min-1.g-1
The estimate for compound 4 lay 1.6-fold (0.20 log units) below the measured number; the range from low to high includes it.
By their numbers in this assay, from the lowest: compound 3; then compounds 2, 1 and 4 (each within the scatter of the next, the first and the last beyond it).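

In this assay, for the compounds shown here, ethoxy in place of ethylamino on a carbonyl carbon gives a 2.3-fold higher number from compound 2 to compound 4 (0.36 log units; beyond the scatter) and so shows that an exchange at this position can move the number beyond the scatter, which the one earlier single change, on the chain of the amide-type nitrogen, did not do. Exchanging isopropylamino for ethoxy at the same carbon gives a 1.8-fold higher number from compound 1 to compound 4 (0.26 log units; within the scatter) and stays within the scatter, so the effect on clearance is modest and is clear only in the comparison with ethylamino. No supporting measurement among these data accounts for the step seen with ethylamino.

As far as these compounds go, how a carboxylic acid, isopropoxy or dimethylamino on this carbonyl carbon would read remains open. So does whether ethoxy in place of ethylamino would give a similar step with a different group on the rest of the molecule.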